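Inverting one stereocentre in compound 1

The source may hold more compounds than are shown below. What is called first, only, known or untested is meant among the compounds shown, and "the series" means these compounds.

In a physicochemical assay for solubility, read by HPLC, in simulated intestinal fluid, with a stated time of 16 h, at pH 6.5, tested at 2.5 mg/mL (a lower number here means a less soluble compound, a higher number a more soluble compound), compound 1 `CNC(=O)c1cc(C(=O)N[C@H]2[C@@H]3C[C@H](O)C[C@@H]32)cc2c1OC[C@@]2(C)c1ccccc1` gives 539 ug/mL. Compound 3 `CNC(=O)c1cc(C(=O)NC2CC2)cc2c1OC[C@@]2(C)c1ccccc1` gives 585 ug/mL, which is a 1.1-fold higher number from compound 1 to compound 3 (0.04 log units; within the scatter), so the two stand level at the top of the three numbers. Compound 2 `CNC(=O)c1cc(C(=O)N[C@H]2C[C@@H]2C)cc2c1OC[C@@]2(C)c1ccccc1` stands apart at 88 ug/mL, which is a 6.1-fold lower number from compound 1 to compound 2 (0.79 log units; beyond the scatter).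

Compound 4 `CNC(=O)c1cc(C(=O)N[C@H]2[C@@H]3C[C@@H](O)C[C@@H]32)cc2c1OC[C@@]2(C)c1ccccc1` is the next to be read. Its relation to the reference is simple: the two compounds have the same atoms and bonds and differ only in configuration as drawn: 1 of 5 stereo elements differ; a stereocentre at a saturated ring carbon is drawn S in compound 1 and R in compound 4.

Among the compounds with values here, no measured step in this set changes configuration alone, so there is no direct precedent. Two steps give only indirect guidance. Replacing the whole group on the amide-type nitrogen gave a 1.1-fold higher number from compound 1 to compound 3 (0.04 log units; within the scatter), whereas the loss of one methyl gave a 6.6-fold higher number from compound 2 to compound 3 (0.82 log units; beyond the scatter). The first shows that a large edit can leave the read-out unmoved. The second shows that a small edit can move it beyond the scatter. With atoms and bonds unchanged, no shift beyond the scatter is expected, though the second step argues for a wide range. The expected step is a 1.1-fold lower number from compound 1 to compound 4 (0.05 log units; within the scatter), and its direction is not firmly predicted. For compound 4 the estimated solubility is 480 ug/mL, with an expected range of 200 ug/mL to 900 ug/mL.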

Compound 4, solubility: > 1000 ug/mL
Compound 4 was reported as a limit; the forecaster's own chance of this, stated with the estimate: 3%; middle value at least 2.0-fold (0.31 log units) from the limit.
By their numbers in this assay, from the lowest: compound 2; then compounds 1 and 3 (each within the scatter of the next). At a limit, above all of these: compound 4.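

In this assay compound 4 gives > 1000 ug/mL, which is a limit and not a number. Configuration at this saturated ring carbon now has a direct reading, an at least 1.8-fold higher number from compound 1 to compound 4 (0.26 log units; that floor lies within the scatter), but that floor lies within the scatter, so the series does not yet show that this inversion alone moves the read-out beyond the scatter, and any shift it does produce can only come from configuration: the fact that compounds 1 and 4 differ only in the configuration as drawn

Against the smaller groups on the amide-type nitrogen, the group of 7 heavy atoms in this configuration gives an at least 1.7-fold higher number from compound 3 to compound 4 (0.23 log units; that floor lies within the scatter), again a floor within the scatter, and an at least 11-fold higher number from compound 2 to compound 4 (1.05 log units; beyond the scatter), which is beyond the scatter.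

The compounds shown leave open how far compound 4 lies past its limit, and so whether the true step from compound 1 exceeds the scatter. They also leave open how an amine or a carboxylic acid in place of the hydroxyl on this ring carbon would read in this assay, in either configuration.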